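Trading 4-Chlorobenzyl for 3-Fluorobenzyl: What to Expect

The source may report more compounds than this note shows. Statements on the series, on what has been measured and on what is new or still open speak of the compounds shown alone.

Compound 1 `C=C(Br)C(=O)Nc1cccc(/C=C2\SC(=O)N(Cc3ccc(Cl)cc3)C2=O)c1` was tested in a functional assay on L1210 cells (Mus musculus) for cytotoxicity, read by cell counting, with a stated time of 2 days (a lower number here means a stronger inhibitor, a higher number a weaker inhibitor), where compound 1 gives 940 nM. Compound 2 `C=C(Br)C(=O)Nc1ccc(/C=C2\SC(=O)N(CC)C2=O)cc1`, built on the same core, gives 500 nM in this assay; the two numbers lie within the usual scatter of each other, so neither compound stands apart. Compound 3 `C=C(Br)C(=O)Nc1cccc(/C=C2\SC(=O)N(Cc3cccc(F)c3)C2=O)c1` has not yet been measured. It differs from compound 1 in one place: 3-fluorophenyl in place of 4-chlorophenyl on a saturated chain carbon bound to an amide-type nitrogen in a ring. Among the compounds with values here, no measured pair shows what such a swap does. The step of a 1.0-fold lower number from compound 1 to compound 3 (0.02 log units; within the scatter) is expected to stay within the scatter, with no clear direction. Compound 3 is estimated at 900 nM, with a range from 350 nM to 2500 nM.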

Compound 3, half-maximal inhibitory concentration: 590 nM
The estimate for compound 3 lay 1.5-fold (0.18 log units) above the measured number; measured number inside the range.
By their numbers in this assay, from the lowest: compounds 2, 3 and 1 (each within the scatter of the next).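

Within the data shown here, this is the first measured step at this position, on a saturated chain carbon bound to an amide-type nitrogen in a ring: in this assay there is a 1.6-fold lower number from compound 1 to compound 3 (0.20 log units; within the scatter). Exchanging 4-chlorophenyl for 3-fluorophenyl therefore shows no clear effect on the cell-killing number for this one pair. No supporting data are available to explain this result.

Going by these compounds, whether this position responds to other groups stays open. An amine, a carboxylic acid or a longer chain in place of the aromatic ring could show whether a step beyond the scatter is possible here.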